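This account rests on a few compounds, and the source may have more. Where it says the series, first, only, none or still open, it means among the compounds named here.

Measured in an ADME assay on the whole organism for pharmacokinetics, with Rattus norvegicus as the target, at a dose of 5 mg/kg by the oral route; a higher number here means more compound in the circulation at the dose given, a lower number less compound in the circulation:
- compound 1 `CC(C)(O)c1ccc(-c2cnc3c(n2)N(CCC2CCOCC2)C(=O)CN3)cn1`: 5560 ng.h/mL
- compound 2 `CC(C)(O)c1ccc(-c2cnc3c(n2)N(CC2CCCCC2)CC(=O)N3)cn1`: "not determined" (no result reported)
- compound 3 `CO[C@H]1CC[C@@H](CN2CC(=O)Nc3ncc(-c4ccc(C(C)(C)O)nc4)nc32)CC1`: "not determined" (no result reported)

Compound 3 has no number in this assay, so it gives no starting value for the step under discussion. Compound 2 is in the same position. Among the compounds with values here, only compound 1 carries a value, and no step between measured compounds is available, so the size of any structural effect on this read-out cannot be taken from the data.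

The next compound is compound 4 `CO[C@H]1CC[C@H](CN2CC(=O)Nc3ncc(-c4ccc(C(C)(C)O)nc4)nc32)CC1`, the partner of compound 3. The change is the two compounds have the same atoms and bonds and differ only in configuration as drawn: 2 of 2 stereo elements differ (all stereocentres are inverted: mirror images); a stereocentre at a saturated ring carbon is drawn s in compound 3 and r in compound 4; a stereocentre at a saturated ring carbon is drawn s in compound 3 and r in compound 4. The atoms and bonds stay the same, and only the configuration as drawn differs.

With no value for compound 3, the step can only be expected in general terms. No shift beyond the usual scatter is expected from this inversion alone, and no direction can be favoured. The estimate therefore rests on compound 1 at 5560 ng.h/mL, the only measured level in the series, and is set somewhat lower with a wide range to allow for the structural distance from that single reference.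

For compound 4 the expected value in this assay is 3000 ng.h/mL, with an estimated range of 800 ng.h/mL to 10000 ng.h/mL.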

Compound 4, area under the concentration-time curve: 2980 ng.h/mL
Compound 4: middle estimate off by 1.0-fold (0.00 log units), on the high side; measured number inside the range.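

In this assay, within the data shown here, compound 4 gives 2980 ng.h/mL and compound 3 carries no single number, so no step between compound 3 and compound 4 can be read. The compounds shown leave open whether inverting both stereocentres at the saturated ring carbons shifts this read-out at all, and in which direction.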